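The source may report more compounds than this note shows. Statements on the series, on what has been measured and on what is new or still open speak of the compounds shown alone.

In an ADME assay on microsomes from liver (Homo sapiens) for metabolic stability, read by HPLC, with a stated time of 10 min, tested at 3 uM; a higher number here means that more of the compound is left, a lower number that less of the compound is left:
- compound 1 `COC[C@H](C1CC1)n1cc(Cl)nc(Nc2cc(C)c(OC)nc2C)c1=O`: 48%
- compound 2 `CC[C@H](C1CC1)n1cc(Cl)nc(Nc2cc(C)c(OC)nc2C)c1=O`: 51%

Among the compounds with values here, compound 2 stands level, within the scatter, with the only other measured compound. Compound 3 `COc1nc(C)c(Nc2nc(Cl)cn([C@H](C)C3CC3)c2=O)cc1C` is still unmeasured. It differs from compound 2 as follows: hydrogen in place of methyl on a saturated chain carbon, two bonds along the chain from an aromatic nitrogen and a saturated ring carbon. That is hydrogen in place of methyl on a saturated chain carbon. Within the data shown here, the one measured change at this place, methyl in place of methoxy, is small: a number 3 percentage points higher from compound 1 to compound 2 (within the scatter). Among the measured compounds shown here, it is the only guide, so no shift beyond the scatter is expected, and the estimated step is a number 4 percentage points higher from compound 2 to compound 3 (within the scatter). For compound 3 the expected value is 55%, with an estimated range of 42% to 68%.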

Compound 3, percent of the compound remaining: 77%
The estimate for compound 3 lay 22 percentage points below the measured number, outside the stated range (above it).
By their numbers in this assay, from the lowest: compounds 1 and 2 (each within the scatter of the next); then compound 3.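

In this assay, this saturated chain carbon turns out to matter: ethyl to methyl, the loss of one carbon, gives a number 26 percentage points higher from compound 2 to compound 3 (beyond the scatter) while methyl in place of methoxy had stayed within the scatter. Hydrogen in place of methoxy at the same carbon gives a number 29 percentage points higher from compound 1 to compound 3 (beyond the scatter) and so sets compound 3 clearly apart from both others. No measurement at hand gives a reason for this step.

Still open, as far as these compounds go, is how a longer chain, such as propyl, or a hydroxyl or fluorine on this carbon would read. Also open, from the compounds shown here alone, is whether 1-cyclopropylethyl keeps its lead when the cyclopropyl ring gives way to an isopropyl group.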